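Sulfanyl in place of cyano on the bis(trifluoromethyl) core

This account rests on a few compounds, and the source may have more. Where it says the series, first, only, none or still open, it means among the compounds named here.

Measured so far in an ADME assay for pharmacokinetics, read by HPLC, in phosphate buffer, with a stated time of 72 h, at pH 7.4, tested at 250 uM; on this read-out lower numbers stand for a shorter-lived compound and higher numbers for a longer-lived compound:
compound 1, `C=CC(=O)Oc1cc(C(F)(F)F)cc(C(F)(F)F)c1`, < 0.017 h
compound 2, `C#Cc1cc(C(F)(F)F)cc(C(F)(F)F)c1`, > 50 h
compound 3, `N#Cc1cc(C(F)(F)F)cc(C(F)(F)F)c1`, > 50 h

The value of compound 1 is a limit of this assay, (the limit of < 0.017 h in this assay, at which 1 of the 3 values shown sits). The value of compound 3 is likewise a limit, (the limit of > 50 h in this assay, at which 2 of the 3 values shown sit), and compound 3 therefore stands at the long-lived end of the numbers shown, together with compound 2, whose value is the same limit. The steps of an at least 2900-fold higher number from compound 1 to compound 2 (3.46 log units; beyond the scatter) and an at least 2900-fold higher number from compound 1 to compound 3 (3.46 log units; beyond the scatter) are large; the step that the two limits leave unreadable from compound 2 to compound 3 cannot be read.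

Compound 4, `FC(F)(F)c1cc(S)cc(C(F)(F)F)c1`, differs from compound 3 by sulfanyl in place of cyano on an aromatic carbon. Within the data shown here, no measured step involves a sulfanyl group, so no step bears directly on this change. Compound 4 is therefore expected to give 40 h in this assay, within 5 h to 200 h, a step of an at least 1.2-fold lower number from compound 3 to compound 4 (0.09 log units; that floor lies within the scatter) whose size is estimated with low confidence.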

Compound 4, half-life: 31.5 h
Compound 4: the middle estimate sits 1.3-fold (0.10 log units) above what was measured; the range from low to high includes it.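

With sulfanyl at this position, compound 4 gives the first half-life on the shared core that is a number rather than a limit. The data give an at least 1.5-fold lower number from compound 3 to compound 4 (0.20 log units; that floor lies within the scatter) and an at least 1.5-fold lower number from compound 2 to compound 4 (0.20 log units; that floor lies within the scatter), so no real drop is shown, while an at least 1800-fold higher number from compound 1 to compound 4 (3.26 log units; beyond the scatter) sets it far from the acrylate ester. Compound 3 stands at a limit of the assay: the limit of > 50 h in this assay, at which 2 of the 4 values shown sit.

Going by these compounds, how far compound 4 truly lies from compound 3 stays open. So does whether an amine or a carboxylic acid at this position would keep the compound as long-lived.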